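Compound 3 to compound 4: exchange on the amide nitrogen

The compounds below may be only part of what the source reports. "The series", "measured", "known", "first", "only" and "open" are said of these compounds alone.

In a functional assay on HeLa cells (Homo sapiens) for antiproliferative activity, read by MTT assay, with a stated time of 72 h (a higher number here means a weaker inhibitor, a lower number a stronger inhibitor), compound 3 (`Cc1noc(C)c1-c1nn(Cc2ccc(C(=O)NC3CC(C)(C)N([O])C(C)(C)C3)cc2)c(=O)c2ccccc12`) gives 83500 nM as the higher of the two actual numbers. Compound 1 (`CN1CCC(NC(=O)c2ccc(Cn3nc(-c4cnn(C)c4)c4ccccc4c3=O)cc2)CC1`) gives 28500 nM in the same assay, a lower number beyond the scatter. Compound 2 (`Cc1noc(C)c1-c1nn(Cc2ccc(C(=O)NC3CC3)cc2)c(=O)c2ccccc12`) reads > 100000 nM and this is a limit of the assay. Compound 4 (`Cc1noc(C)c1-c1nn(Cc2ccc(C(=O)NC3CCN(C)CC3)cc2)c(=O)c2ccccc12`) carries 1-methylpiperidin-4-yl on the amide-type nitrogen, described as a group of 7 heavy atoms (6 carbon, 1 nitrogen; one six-membered non-aromatic ring with 1 hetero atom) in place of a group of 11 heavy atoms (9 carbon, 1 nitrogen, 1 oxygen; one six-membered non-aromatic ring with 1 hetero atom), on an amide-type nitrogen in the change from compound 3. For the measured compounds named here, the one measured step at this nitrogen is an at least 1.1-fold lower number from compound 2 to compound 3 (0.07 log units; that floor lies within the scatter) and it therefore sets no clear size. Expected in this assay is a 1.4-fold lower number from compound 3 to compound 4 (0.14 log units; within the scatter) with no move beyond the scatter foreseen. The estimate for compound 4 is 60000 nM with an expected range from 25000 nM to 130000 nM in this assay.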

Compound 4, half-maximal inhibitory concentration: > 100000 nM
Compound 4 gave a limit, no number; the forecaster's own chance of this, stated with the estimate: 25%; middle value at least 1.6-fold (0.22 log units) from the limit.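

In this assay, 1-methylpiperidin-4-yl on the amide-type nitrogen brings no readable gain over the group it replaces: an at least 1.1-fold higher number from compound 3 to compound 4 (0.07 log units; that floor lies within the scatter). For the compounds shown here, with that amide group held fixed, the first readable step at the other site appears, with 3,5-dimethyl-1,2-oxazol-4-yl in place of 1-methyl-1H-pyrazol-4-yl on an aromatic carbon: an at least 3.5-fold higher number from compound 1 to compound 4 (0.54 log units; beyond the scatter). The step between compound 2 and compound 4 cannot be read, because both values are limits of the assay: the limit of > 100000 nM in this assay, at which 2 of the 4 values shown sit.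

Open, from the compounds shown here alone, is how a primary amine or a carboxylic acid on the amide-type nitrogen would read with 3,5-dimethyl-1,2-oxazol-4-yl kept.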